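Moving the hydroxyl in a thiophene-bearing compound

The compounds below may be only part of what the source reports. "The series", "measured", "known", "first", "only" and "open" are said of these compounds alone.

Compound 1 `Oc1ccc(-c2cc(-c3cccc(Cl)c3)nc(-c3ccccn3)c2)cc1` gives 27900 nM
Compound 2 `Oc1ccc(-c2cc(-c3cccnc3)nc(-c3cccc(Cl)c3)c2)cc1` gives 25700 nM
Compound 3 `Oc1cccc(-c2cc(-c3ccsc3)nc(-c3cccc(Cl)c3)c2)c1` gives 3540 nM

In a functional assay on T47D cells (Homo sapiens) for cytotoxicity, read by CCK-8 assay and cell counting, with a stated time of 2 days (on this read-out lower numbers stand for stronger inhibition and higher numbers for weaker inhibition), compound 3 at 3540 nM has the lowest of the three numbers, and its gap to each of the others lies beyond the scatter. Compound 4 `Oc1ccc(-c2cc(-c3ccsc3)nc(-c3cccc(Cl)c3)c2)cc1` has the same atoms joined differently. The change 4-hydroxyphenyl in place of 3-hydroxyphenyl on an aromatic carbon puts 4-hydroxyphenyl in place of 3-hydroxyphenyl on an aromatic carbon. Within the data shown here, no measured step isolates this change. Among the measured compounds shown here, the only step available, a 1.1-fold lower number from compound 1 to compound 2 (0.04 log units; within the scatter), leaves the hydroxyphenyl group untouched. Compound 1 at 27900 nM and compound 2 at 25700 nM both carry 4-hydroxyphenyl, as compound 4 will. Compound 3 alone carries 3-hydroxyphenyl and thiophen-3-yl, and the data cannot separate these two features. Compound 4 keeps thiophen-3-yl, so only part of that gap is expected to return. In this assay the expected step is a 2.3-fold higher number from compound 3 to compound 4 (0.35 log units; beyond the scatter) and its size is uncertain. For compound 4 the estimated value is 8000 nM within an expected range from 2500 nM to 22000 nM on present evidence.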

Compound 4, half-maximal inhibitory concentration: 7390 nM
Beside the measured number, compound 4's estimate is 1.1-fold (0.03 log units) above it; measured number inside the range.
By their numbers in this assay, from the lowest: compound 3; then compound 4; then compounds 2 and 1 (each within the scatter of the next).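

In this assay the position opposite the ring nitrogen can now be read on its own: 4-hydroxyphenyl in place of 3-hydroxyphenyl gives a 2.1-fold higher number from compound 3 to compound 4 (0.32 log units; beyond the scatter) and so carries a modest cost. With 4-hydroxyphenyl held fixed, thiophen-3-yl in place of pyridin-3-yl gives a 3.5-fold lower number from compound 2 to compound 4 (0.54 log units; beyond the scatter) and in place of pyridin-2-yl gives a 3.8-fold lower number from compound 1 to compound 4 (0.58 log units; beyond the scatter) while the earlier exchange between the two pyridine groups stayed within the scatter. Nothing available explains either difference.

As far as these compounds go, it remains open whether the hydroxyl shift has the same size when a pyridine group replaces thiophen-3-yl. The compounds shown also leave open whether a methoxy group or an amine could stand in for the hydroxyl, and what the 3-chlorophenyl group, present in all four, contributes.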